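Swapping Chloro for Trifluoromethoxy: Cytotoxicity at the Limit

The source may hold more compounds than are shown below. What is called first, only, known or untested is meant among the compounds shown, and "the series" means these compounds.

Compound 1 `CNC(=S)N/N=C1\C(=O)Nc2ccccc21`: > 25000 nM
Compound 2 `O=C1Nc2ccc(Cl)cc2/C1=N/NC(=S)Nc1ccccc1`: > 25000 nM
Compound 3 `COc1cccc(NC(=S)N/N=C2\C(=O)Nc3ccccc32)c1`: > 25000 nM

All three compounds were tested in an ADME assay on RD cells (Homo sapiens) for cytotoxicity; on this read-out higher numbers stand for lower toxicity in this test and lower numbers for higher toxicity in this test. For compound 1 the result > 25000 nM is a limit of the assay, not a number. For compound 2 the result > 25000 nM is likewise a limit. Compound 3 too sits at that limit with > 25000 nM. Compound 2 therefore stands where every measured value stands, at the limit of > 25000 nM in this assay, at which 3 of the 3 values shown sit. Compound 4 `O=C1Nc2ccc(OC(F)(F)F)cc2/C1=N/NC(=S)Nc1ccccc1` differs from compound 2 by trifluoromethoxy in place of chloro on an aromatic carbon. Within the data shown here, no measured pair shows how such a change moves this read-out, so the estimated step that the limit leaves unreadable from compound 2 to compound 4 is expected to stay within the scatter. Compound 4 is accordingly expected to give about 30000 nM, somewhere between 12000 nM and 80000 nM, and most likely again only as a limit.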

Compound 4, half-maximal cytotoxic concentration: > 25000 nM
Compound 4 was reported as a limit (the forecaster's own chance of this, stated with the estimate: 80%); the middle value lies beyond the limit too.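

Compound 2 and compound 4 both give only a limit, so no step can be read from trading chloro for trifluoromethoxy: the limit of > 25000 nM in this assay, at which 4 of the 4 values shown sit. The compounds shown leave open at what concentration, if any, any of them would harm these cells.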